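Hydrazone series: loss of bromine from compound 3

The source may report more compounds than this note shows. Statements on the series, on what has been measured and on what is new or still open speak of the compounds shown alone.

Compound 1 `O=C(CSc1nnc(-c2ccncc2)n1-c1ccccc1)N/N=C/c1ccc(Br)cc1` gives 7040 nM in a functional assay on MCF7 cells (Homo sapiens) for inhibition, read by MTT assay, with a stated time of 48 h; a higher number here means a weaker inhibitor, a lower number a stronger inhibitor. Compound 2 `O=C(CSc1nnc(-c2ccncc2)n1-c1ccccc1)N/N=C/c1ccc(Cl)cc1` gives 9930 nM, and a 1.4-fold higher number from compound 1 to compound 2 (0.15 log units; within the scatter). Compound 3 `O=C(CSc1nnc(-c2ccncc2)n1-c1ccccc1)N/N=C/c1cc(Br)ccc1O` gives 6460 nM and stands at the lowest of the three numbers shown, although a 1.1-fold lower number from compound 1 to compound 3 (0.04 log units; within the scatter) and a 1.5-fold lower number from compound 2 to compound 3 (0.19 log units; within the scatter), so the three cannot be ordered. Compound 4 `O=C(CSc1nnc(-c2ccncc2)n1-c1ccccc1)N/N=C/c1ccccc1O` differs from compound 3 by hydrogen in place of bromo on an aromatic carbon. Within the data shown here, no measured step removes a halogen outright; the nearest comparison is the halogen swap a 1.4-fold higher number from compound 1 to compound 2 (0.15 log units; within the scatter), which was small. Compound 4 is therefore expected to give 9500 nM. The expected range for compound 4 runs from 4500 nM to 20000 nM. The expected step of a 1.5-fold higher number from compound 3 to compound 4 (0.17 log units; within the scatter) is a modest rise in the number, with no confidence that it exceeds the scatter.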

Compound 4, half-maximal inhibitory concentration: 10000 nM
For compound 4 the middle estimate is 1.1-fold (0.02 log units) below the measured one, and the stated range covers the measured number.
By their numbers in this assay, from the lowest: compounds 3, 1, 2 and 4 (each within the scatter of the next).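

Among these compounds, replacing the bromo para to the hydroxy group is the first outright loss of a halogen, and a 1.5-fold higher number from compound 3 to compound 4 (0.19 log units; within the scatter) shows that in this assay this position gives no readable difference between bromo and hydrogen. The 2-hydroxyphenyl compound also stays unseparated from the 4-chlorophenyl compound, with a 1.0-fold higher number from compound 2 to compound 4 (0.00 log units; within the scatter), and from the 4-bromophenyl compound, with a 1.4-fold higher number from compound 1 to compound 4 (0.15 log units; within the scatter). No evidence on the cause of this flat result is available here.

Open, going by these compounds, is whether any group at this position separates from the scatter. An amine or a carboxylic acid in place of the bromo would bear on that.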